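Swapping the Aryl Group Across Two Related Cores

The compounds below may be only part of what the source reports. "The series", "measured", "known", "first", "only" and "open" are said of these compounds alone.

Measured in a functional assay on MCF7 cells (Homo sapiens) for cytotoxicity, read by MTT assay, with a stated time of 72 h; on this read-out lower numbers stand for stronger inhibition and higher numbers for weaker inhibition:
compound 1 `Cc1cc(=O)n(-c2ccccc2C(F)(F)F)nc1C(=O)Nc1ccc(Oc2ncnc3ccsc23)c(F)c1`: 6020 nM
compound 2 `Cc1cc(=O)n(-c2ccc(Br)cc2F)nc1C(=O)Nc1ccc(Oc2ncnc3ccsc23)c(F)c1`: 1550 nM
compound 3 `Cc1cc(=O)n(-c2ccccc2C(F)(F)F)nc1C(=O)Nc1ccc(Oc2ncnc3sccc23)cc1`: > 40000 nM, a limit of the assay rather than a number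

In this assay the move from compound 1 to compound 2 is 4-bromo-2-fluorophenyl in place of 2-(trifluoromethyl)phenyl on an aromatic nitrogen, and it gave a 3.9-fold lower number from compound 1 to compound 2 (0.59 log units; beyond the scatter). Compound 4 `Cc1cc(=O)n(-c2ccc(Br)cc2F)nc1C(=O)Nc1ccc(Oc2ncnc3sccc23)cc1` has not been measured; it differs from compound 3 by 4-bromo-2-fluorophenyl in place of 2-(trifluoromethyl)phenyl on an aromatic nitrogen, the same change at the same place. The difference between the core of compound 1 and the core of compound 3 is not broken down here. Compound 4 is expected to show an at least 2.0-fold lower number from compound 3 to compound 4 (0.30 log units; that floor lies within the scatter), resting on a 3.9-fold lower number from compound 1 to compound 2 (0.59 log units; beyond the scatter). Compound 3 is known only as a limit, > 40000 nM. The estimate for compound 4 is 20000 nM, from 6000 nM to 80000 nM, and a limit again is quite possible.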

Compound 4, half-maximal inhibitory concentration: 15200 nM
Compound 4: middle estimate off by 1.3-fold (0.12 log units), on the high side; measured number inside the range.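

In this assay, the change to 4-bromo-2-fluorophenyl in place of 2-(trifluoromethyl)phenyl carries over to the second core, with an at least 2.6-fold lower number from compound 3 to compound 4 (0.42 log units; beyond the scatter). On these data alone, compound 3 is known only as a limit of the assay, > 40000 nM, and the full size of this step stays unknown. The change therefore lowers the number on both cores, but whether it does so by the same amount on each cannot be said: the same change on two cores in this assay, a 3.9-fold lower number (0.59 log units; beyond the scatter) from compound 1 to compound 2 and an at least 2.6-fold lower number (0.42 log units; beyond the scatter) from compound 3 to compound 4; the limit leaves it open whether they differ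

The compounds shown cover only two groups on the aromatic nitrogen and only two cores. As far as these compounds go, how an unsubstituted phenyl, or a phenyl carrying an amine or a carboxylic acid, would compare on these cores stays open, as does whether the change holds on any further core.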